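Swapping the amide-bearing arm for a methylbenzyl group

This account rests on a few compounds, and the source may have more. Where it says the series, first, only, none or still open, it means among the compounds named here.

In an ADME assay on HEK-293T cells (Homo sapiens) for inhibition, read by MTT assay, with a stated time of 48 h (on this read-out higher numbers stand for weaker inhibition and lower numbers for stronger inhibition), compound 1 `COc1cc(-c2nc3cc(/C=C4\SC(=O)NC4=O)ccc3[nH]2)ccc1OCC(C)C` gives 14100 nM. Compound 2 `COc1cc(-c2nc3cc(/C=C4\SC(=O)N(CC(=O)N5CCOCC5)C4=O)ccc3[nH]2)cc(OC)c1OC` gives 18800 nM in this assay, and compound 3 `COc1cc(-c2nc3cc(/C=C4\SC(=O)N(CC(=O)N5CCCC5)C4=O)ccc3[nH]2)cc(OC)c1OC` gives 12700 nM. Within the data shown here, the only step between neighbours that differ in one place is a 1.5-fold lower number from compound 2 to compound 3 (0.17 log units; within the scatter). Compound 3 thus carries the lowest of the three numbers, yet its gaps to compound 1 and to compound 2 both lie within the scatter, so no order among the three can be claimed.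

Compound 4 `COc1cc(-c2nc3cc(/C=C4\SC(=O)N(Cc5cccc(C)c5)C4=O)ccc3[nH]2)cc(OC)c1OC` differs from compound 3 by 3-methylphenyl in place of (pyrrolidin-1-yl)carbonyl on a saturated chain carbon bound to an amide-type nitrogen in a ring. Among the measured compounds shown here, no measured step covers this kind of change; the step from compound 2 to compound 3 touched the same chain, but only exchanged one saturated ring for another on the carbonyl carbon and stayed within the scatter. With nothing in the data pointing either way, the expected step is a 1.1-fold lower number from compound 3 to compound 4 (0.02 log units; within the scatter), none beyond the scatter. Compound 4 is therefore estimated to give 12000 nM in this assay, within a range from 4500 nM to 32000 nM.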

Compound 4, half-maximal inhibitory concentration: 18900 nM
Estimate against measurement, compound 4: 1.6-fold (0.20 log units) below, and the stated range covers the measured number.
By their numbers in this assay, from the lowest: compounds 3, 1, 2 and 4 (each within the scatter of the next).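

In this assay, the saturated chain carbon bound to an amide-type nitrogen in a ring takes a change of a different kind from the earlier exchange of one saturated ring for another: 3-methylphenyl in place of (pyrrolidin-1-yl)carbonyl gives a 1.5-fold higher number from compound 3 to compound 4 (0.17 log units; within the scatter), and 3-methylphenyl in place of (morpholin-4-yl)carbonyl gives a 1.0-fold higher number from compound 2 to compound 4 (0.00 log units; within the scatter), so neither step can be read as a change. Here the carbonyl and the saturated ring leave and a six-membered aromatic ring of carbon only enters, and the number shows no effect beyond the scatter. Nothing available bears on why this is so.

Going by these compounds, whether a carboxylic acid or an amine on this chain carbon, or a longer chain carrying the same aromatic ring, would move the number beyond the scatter stays open. Also open, on these data alone, is how an unsubstituted benzyl group would compare with 3-methylbenzyl.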